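A few compounds are considered here, and "the series" means these few. Any claim that something is new, unique, unknown or untested is made for them only; others in the source may bear on it.

Compound 1 `N#Cc1ccccc1NC(=O)N1CCC(c2nc(-c3ccc4ccccc4n3)no2)CC1`: 190 nM
Compound 2 `O=C(NC1CCCCC1)N1CCC(c2nc(-c3ccc4ccccc4n3)no2)CC1`: 57 nM
Compound 3 `O=C(NC1CCC(O)CC1)N1CCC(c2nc(-c3ccc4ccccc4n3)no2)CC1`: 2700 nM

All three share one core and were tested in a functional assay on Shh Light II cells (Mus musculus) for inhibition, read by a luciferase reporter; a lower number here means a stronger inhibitor, a higher number a weaker inhibitor. Compound 1 gives 190 nM, the second highest of the three numbers. Compound 2 gives 57 nM, and compound 3 gives 2700 nM.

Compound 4 `O=C(OCc1ccccc1)N1CCC(c2nc(-c3ccc4ccccc4n3)no2)CC1` differs from compound 1 in one place: benzyloxy in place of (2-cyanophenyl)amino on a carbonyl carbon. The group that leaves carries a hydrogen-bond donor; the group that enters carries none.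

Two measured steps alter the same partner of the carbonyl: a 3.3-fold lower number from compound 1 to compound 2 (0.52 log units; beyond the scatter) and a 14-fold higher number from compound 1 to compound 3 (1.15 log units; beyond the scatter). The step of a 47-fold higher number from compound 2 to compound 3 (1.68 log units; beyond the scatter) separates those two outcomes. None of these steps exchanges the amide-type nitrogen for an oxygen, so they show only that this position answers to change in both directions, with gains small and losses large. A modest weakening, or none beyond the scatter, is therefore expected: a 1.8-fold higher number from compound 1 to compound 4 (0.27 log units; within the scatter). Compound 4 is estimated at 350 nM, within a range of 90 nM to 1400 nM.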

Compound 4, half-maximal inhibitory concentration: > 2500 nM
Compound 4: only a limit was reported; the forecaster's own chance of this, stated with the estimate: 5%; at least 7.1-fold (0.85 log units) between middle value and limit.
By their numbers in this assay, from the lowest: compound 2; then compound 1; then compound 3.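

In this assay compound 4 gives > 2500 nM, which is a limit and not a number: the limit of > 2500 nM in this assay, at which 1 of the 4 values shown sits. Benzyloxy on the carbonyl carbon gives an at least 13-fold higher number from compound 1 to compound 4 (1.11 log units; beyond the scatter), and the same group in place of cyclohexylamino gives an at least 43-fold higher number from compound 2 to compound 4 (1.64 log units; beyond the scatter). For the compounds shown here, the earlier compounds all kept the amide-type nitrogen with its hydrogen and changed only what it carried, so this is the first sign that exchanging that nitrogen for an oxygen, which removes the hydrogen-bond donor, goes with a large loss.

The step from compound 3 to compound 4 cannot be read. The compounds shown also cannot separate the loss of the donor from the change of the attached group, a question that benzylamino on the same carbonyl carbon would address.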